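The compounds below may be only part of what the source reports. "The series", "measured", "known", "first", "only" and "open" are said of these compounds alone.

Compound 2 `COc1ccc(N(C)c2nc(C)nc3ccccc23)cc1OCCCCC[Se]C#N` gives the highest number of the three measured in a functional assay on HepG2 cells (Homo sapiens) for inhibition, read by MTT assay, with a stated time of 48 h (a higher number here means a weaker inhibitor, a lower number a stronger inhibitor), at 5210 nM. Compound 3 `CN(c1ccc([Se]C#N)cc1)c1nc(C2CC2)nc2ccccc12` gives 41 nM in this assay, and compound 1 `C[Se]c1ccc(N(C)c2nc(C)nc3ccccc23)cc1C` gives 6 nM; both sit far below compound 2, well beyond the scatter. Compound 4 `COc1ccc(N(C)c2nc(C)nc3ccccc23)cc1OCCC[Se]C#N` keeps the core and the methoxy of compound 2 and differs only in the chain: a group of 3 heavy atoms (1 carbon, 1 nitrogen, 1 selenium; no ring) in place of a group of 5 heavy atoms (3 carbon, 1 nitrogen, 1 selenium; no ring), on a saturated chain carbon, three bonds along the chain from an oxygen on an aromatic ring. Going by the values given here, no measured pair shows this shortening, so its effect is unknown; a modest step toward a lower number is expected, and it may still fall within the scatter. Compound 4 is therefore estimated at 3000 nM, with a range of 700 nM to 13000 nM, which corresponds to an expected step of a 1.7-fold lower number from compound 2 to compound 4 (0.24 log units; within the scatter).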

Compound 4, half-maximal inhibitory concentration: 1040 nM
Compound 4: middle estimate off by 2.9-fold (0.46 log units), on the high side; measured number inside the range.
By their numbers in this assay, from the lowest: compound 1; then compound 3; then compound 4; then compound 2.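

In this assay, a group of 3 heavy atoms in place of a group of 5 heavy atoms gives a 5.0-fold lower number from compound 2 to compound 4 (0.70 log units; beyond the scatter). Going by these compounds alone, this is the first measured pair differing in one place, and it shows that the number responds to chain length on this saturated chain carbon, three bonds along the chain from an oxygen on an aromatic ring. Nothing measured here explains the step. With only two chain lengths shown, the trend remains a single step. As far as these compounds go, how a shorter or longer chain, or an amine or a carboxylic acid in this place, would compare stays open.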